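Naphthalen-1-yl Replaces 4-Formylphenyl on a Shared Core

A few compounds are considered here, and "the series" means these few. Any claim that something is new, unique, unknown or untested is made for them only; others in the source may bear on it.

Measured compounds:
compound 1, `Cc1cccc(-c2cn3ccnc3c(-c3ccc4ncn(Cc5ccccc5)c4c3)n2)c1`: 21.7%
compound 2, `O=Cc1ccc(-c2cn3ccnc3c(-c3ccc4ncn(Cc5ccccc5)c4c3)n2)cc1`: 21.4%

In a functional assay on SNB-75 cells (Homo sapiens) for inhibition, read by sulforhodamine B assay, with a stated time of 48 h, tested at 10 uM (on this read-out higher numbers stand for more inhibition at the one concentration tested (going by the name of the read-out) and lower numbers for less inhibition), compound 1 gives 21.7%, and compound 2 gives 21.4%. Compound 2 is the lowest of the two numbers, but its nearest neighbour is compound 1 with a number 0.3 percentage points lower from compound 1 to compound 2 (within the scatter), so the two compounds cannot be told apart on this read-out.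

Compound 3, `c1ccc(Cn2cnc3ccc(-c4nc(-c5cccc6ccccc56)cn5ccnc45)cc32)cc1`, has not yet been measured in this assay. It differs from compound 2 in one place: naphthalen-1-yl in place of 4-formylphenyl on an aromatic carbon.

Within the data shown here, only one measured step exists, the one from compound 1 to compound 2, and it concerns a different exchange of aryl groups at the same aromatic carbon; its size was a number 0.3 percentage points lower from compound 1 to compound 2 (within the scatter). That step bears on the present change only loosely, since it shows that swapping one aryl group for another at this position left the number where it stood. Among the measured compounds shown here, no measured step covers the entry of naphthalen-1-yl itself.

On that basis compound 3 is expected to stay near compound 2, with an estimated step of a number 0.6 percentage points higher from compound 2 to compound 3 (within the scatter), not beyond the scatter. Compound 3 is therefore estimated at 22%, within a range from 8% to 40%.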

Compound 3, a percentage reported as inhibition, at one concentration (the size of the read-out at that concentration, not a potency): 16.2%
Estimate against measurement, compound 3: 5.8 percentage points above; the measured number falls inside the stated range.
By their numbers in this assay, from the lowest: compounds 3, 2 and 1 (each within the scatter of the next).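

Among these compounds, with naphthalen-1-yl, this aromatic carbon now carries a group of two six-membered aromatic rings of carbon only, whereas the earlier compounds carried a single such ring, and in this assay this exchange gives a number 5.2 percentage points lower from compound 2 to compound 3 (within the scatter) and a number 5.5 percentage points lower from compound 1 to compound 3 (within the scatter). The 4-formylphenyl group also takes its hydrogen-bond acceptor and its double bond outside aromatic rings with it, and neither that loss nor the added ring carries either step beyond the scatter, so all three aryl groups at this position remain indistinguishable on this read-out. Among the compounds shown here, no independent measurement bears on why the numbers stay together, and the single exchange offers no explanation of its own.

The compounds shown leave open whether an aryl group bearing an amine or a carboxylic acid, or a morpholine ring on this same aromatic carbon, would move the number beyond the scatter. They also leave open how the compounds would compare at other concentrations, since a percentage at one concentration says nothing about potency, and whether any change elsewhere on the shared core, such as at the benzyl group, would matter more.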